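Removing the Amino Group from a Purine-Like Core

A few compounds are considered here, and "the series" means these few. Any claim that something is new, unique, unknown or untested is made for them only; others in the source may bear on it.

Of the compounds shown here, three have been tested in a functional assay on OVCAR-5 cells (Homo sapiens) for cytotoxicity, read by sulforhodamine B assay, with a stated time of 48 h; a higher number here means a weaker inhibitor of growth, a lower number a stronger inhibitor of growth. Compound 1, `Nc1nc(Cl)c2ncn(Cc3ccccc3CCl)c2n1`, gives 20000 nM. Compound 2, `ClCc1cccc(Cn2cnc3nc(Cl)nc(Cl)c32)c1`, gives 1690 nM, and compound 3, `ClCc1ccc(Cn2cnc3c(Cl)nc(Cl)nc32)cc1`, gives 18200 nM. Compound 1 therefore has the highest of the three numbers; its number and that of compound 3 lie within the scatter of each other, while compound 2 sits well below both, beyond the scatter.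

Compound 4, `ClCc1ccccc1Cn1cnc2c(Cl)ncnc21`, has not yet been measured. It differs from compound 1 in one place: hydrogen in place of amino on an aromatic carbon. Within the data shown here, no pair of measured compounds differs in just this way, so the size of this change cannot be read off directly; compounds 2 and 3 lack the amino group but also carry a different arrangement elsewhere.

With nothing more to rest on, compound 4 is expected to stay near compound 1, with a step of a 1.3-fold lower number from compound 1 to compound 4 (0.12 log units; within the scatter) that lies within the usual scatter. Compound 4 is estimated at 15000 nM, with a likely range from 4000 nM to 50000 nM.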

Compound 4, concentration for 50% growth inhibition: 2450 nM
Estimate against measurement, compound 4: 6.1-fold (0.79 log units) above, outside the stated range (below it).
By their numbers in this assay, from the lowest: compounds 2 and 4 (each within the scatter of the next); then compounds 3 and 1 (each within the scatter of the next).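

Removing the amino group from the aromatic carbon between two ring nitrogen atoms gives, in this assay, an 8.2-fold lower number from compound 1 to compound 4 (0.91 log units; beyond the scatter). This position therefore matters: with the rest of the molecule unchanged, hydrogen there goes with stronger inhibition of growth than amino does. No measurement here bears on why the number moves, so the change can be described but not explained.

As far as these compounds go, this is a single pair, so it remains open whether another small group at this position, such as methyl, methoxy or fluoro, would give a number nearer that of compound 4 or that of compound 1. From the compounds shown here alone, it also remains open whether swapping amino for hydrogen would produce a step of similar size in compounds that differ elsewhere in the molecule.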